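Para-methyl on the phenyl of a purine adenosine A3 ligand

The source may report more compounds than this note shows. Statements on the series, on what has been measured and on what is new or still open speak of the compounds shown alone.

In an assay on CHO cells for displacement of a labelled ligand from adenosine receptor A3 (Homo sapiens), read by scintillation counting, with a stated time of 3 h (on this read-out higher numbers stand for weaker inhibition and lower numbers for stronger inhibition), three compounds have been measured:

Compound 1 `Cn1c(-c2ccccc2)nc2c(NC3CCCC3)ncnc21` gives 846 nM.
Compound 2 `Cn1c(-c2ccccc2)nc2c(NC3CCC3)ncnc21` gives 280 nM.
Compound 3 `CCn1c(-c2ccccc2)nc2c(NC3CCOC3)ncnc21` gives 1660 nM.

Compound 1 stands second highest of the three numbers. Its nearest neighbour is compound 3, whose value lies within the scatter of that of compound 1, so the two cannot be ordered. Among the measured compounds shown here, the only step between measured compounds that differ in one place is a 3.0-fold lower number from compound 1 to compound 2 (0.48 log units; beyond the scatter), a modest change that lies beyond the scatter.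

Compound 4 `Cc1ccc(-c2nc3c(NC4CCCC4)ncnc3n2C)cc1` differs from compound 1 only on the phenyl ring: methyl in place of hydrogen on an aromatic carbon. For the measured compounds named here, no measured step in this set touches the phenyl group; the one step that is known concerns the cycloalkyl group on the nitrogen and so says nothing about this change. Going by the values given here, with no bearing step to draw on, the expectation for compound 4 is a value close to that of compound 1, with no step beyond the scatter in either direction.

Compound 4 is therefore estimated at 750 nM, with a range from 250 nM to 2300 nM. The expected step is a 1.1-fold lower number from compound 1 to compound 4 (0.05 log units; within the scatter), which amounts to no change beyond the scatter.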

Compound 4, inhibition constant: 480 nM
Compound 4: the middle estimate sits 1.6-fold (0.19 log units) above what was measured; measured number inside the range.
By their numbers in this assay, from the lowest: compounds 2, 4, 1 and 3 (each within the scatter of the next, the first and the last beyond it).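

In this assay, among the compounds shown here, the change from phenyl to 4-methylphenyl, methyl in place of hydrogen on an aromatic carbon para to a large group, gives the first measured step on this ring (a 1.8-fold lower number from compound 1 to compound 4 (0.25 log units; within the scatter)), and that step stays within the scatter. For the compounds shown here, with cyclopentyl on the nitrogen, this position therefore carries a methyl with no change that can be told from the scatter, whereas the one earlier step, which lies in another part of the molecule (a 3.0-fold lower number from compound 1 to compound 2 (0.48 log units; beyond the scatter)), goes beyond it. No measurement at hand offers an explanation of this result.

Going by these compounds alone, whether a methoxy, a chlorine, an amine or a carboxylic acid at the same place would give a step beyond the scatter remains open, as does whether a methyl on another aromatic carbon of this ring would behave like the one in compound 4. Also open, going by these compounds, is whether the same methyl would give a comparable step with cyclobutyl on the nitrogen, as in compound 2, or with the oxygen-containing ring of compound 3.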